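Swapping Fluoro for Methoxy on Compound 1

The source may hold more compounds than are shown below. What is called first, only, known or untested is meant among the compounds shown, and "the series" means these compounds.

Compound 1 `Cc1nnc(SCC(=O)N/N=c2/scc(-c3ccc(F)cc3)n2-c2ccccc2)s1` gives, in a functional assay on C6 cells (Rattus norvegicus) for cytotoxicity, read by MTT assay, with a stated time of 24 h, tested at 100 ug/mL (on this read-out higher numbers stand for a weaker effect at the one concentration tested and lower numbers for a stronger effect), 34.9%, the lowest of the three numbers shown, though both companions lie within the usual scatter of it: compound 3 `O=C(CSc1nnnn1-c1ccccc1)N/N=c1/scc(-c2ccc(F)cc2)n1-c1ccccc1` gives 35.8%, and compound 2 `Cc1ccc(-c2cs/c(=N/NC(=O)CSc3nncn3C)n2-c2ccccc2)cc1` gives 39.6%. Among the measured compounds shown here, the one measured step, a number 0.9 percentage points higher from compound 1 to compound 3 (within the scatter), changes only the group on the sulfur. Compound 4 `COc1ccc(-c2cs/c(=N/NC(=O)CSc3nnc(C)s3)n2-c2ccccc2)cc1` differs from compound 1 as follows: methoxy in place of fluoro on an aromatic carbon. For the measured compounds named here, no measured step touches this ring; compound 2 carries a different group there alongside a second change, so its value alone settles nothing. With every measured difference here lying within the scatter, the step of a number 2.1 percentage points higher from compound 1 to compound 4 (within the scatter) is expected to be small, in no clear direction. Compound 4 is therefore estimated at 37%, with a range from 27% to 48%.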

Compound 4, a percentage reported as activity, at one concentration (the size of the read-out at that concentration, not a potency): 25.9%
Beside the measured number, compound 4's estimate is 11.1 percentage points above it; measured number outside the range, below it.
By their numbers in this assay, from the lowest: compounds 4, 1, 3 and 2 (each within the scatter of the next, the first and the last beyond it).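

In this assay, among the compounds shown here, the step of a number 9 percentage points lower from compound 1 to compound 4 (within the scatter) is the first measured change confined to this aromatic ring. It shows that going from 4-fluorophenyl to 4-methoxyphenyl, para to a large group, leaves the read-out within the usual scatter. Nothing measured here bears on a cause for this result.

Going by these compounds, whether an amine, a carboxylic acid or a longer chain such as butoxy on this carbon would carry the read-out beyond the scatter remains open. So does whether the same swap behaves alike with 1-phenyl-1H-tetrazol-5-yl on the sulfur.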